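A few compounds are considered here, and "the series" means these few. Any claim that something is new, unique, unknown or untested is made for them only; others in the source may bear on it.

Compound 1, `CNc1ccc(/C=C/c2c(F)cccc2F)cc1`, gives 7.6 nM in a functional assay on LS174T cells (Homo sapiens) for antiproliferative activity; on this read-out lower numbers stand for stronger inhibition and higher numbers for weaker inhibition.
Compound 2, `CCNc1ccc(/C=C/c2c(F)cccc2F)cc1`, gives 200 nM in this assay.
Compound 3, `CNc1ccc(/C=C/c2c(F)cccc2F)cn1`, gives 30.1 nM in this assay.

Compound 1 and compound 2 share a core and differ in one place: methyl in place of hydrogen on a saturated chain carbon bound to a nitrogen on an aromatic ring. This change brought a 26-fold higher number from compound 1 to compound 2 (1.42 log units; beyond the scatter), a large loss of inhibition on the cells. Compound 3 carries a different core from compound 1; how the two cores differ is not broken down here, and the numbers alone show that compound 3 gives a higher number than compound 1 in this assay.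

Compound 4, `CCNc1ccc(/C=C/c2c(F)cccc2F)cn1`, has not yet been tested. It differs from compound 3 in exactly the way compound 2 differs from compound 1: methyl in place of hydrogen on a saturated chain carbon bound to a nitrogen on an aromatic ring. Going by the values given here, since the place of the change is the same in both pairs, the expectation for compound 4 rests on the single measured step, which was a 26-fold higher number from compound 1 to compound 2 (1.42 log units; beyond the scatter). Among the compounds with values here, a step of similar size is expected from compound 3 to compound 4, namely a 20-fold higher number from compound 3 to compound 4 (1.30 log units; beyond the scatter), although with only one prior example the size is uncertain. Compound 4 is therefore estimated at 600 nM in this assay, within roughly 150 nM to 2500 nM.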

Compound 4, half-maximal inhibitory concentration: 31.3 nM
For compound 4 the middle estimate is 19-fold (1.28 log units) above the measured one, and the stated range ends above it.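

On the core of compound 3, the change from methylamino to ethylamino brought a 1.0-fold higher number from compound 3 to compound 4 (0.02 log units; within the scatter) in this assay, so the large loss of inhibition seen with the same change on the core of compound 1 did not carry over to this second core. In this series, then, the size of the step depends on the core that carries it, and the two steps lie further apart than their scatter allows: the same change on two cores in this assay, a 26-fold higher number (1.42 log units; beyond the scatter) from compound 1 to compound 2 and a 1.0-fold higher number (0.02 log units; within the scatter) from compound 3 to compound 4, 25-fold (1.40 log units) apart, beyond the scatter of two such steps

Going by these compounds alone, with only two cores compared, this does not show which feature of the cores sets the difference, nor what the same change would bring on any further core.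

The compounds shown leave open whether a longer chain, such as propyl in place of ethyl, would follow the pattern of the core of compound 1 or that of the core of compound 3. They also leave open how a primary amine or a dimethylamino group would behave on either core.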